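Maximal cAMP response in the cyclohexyl-linked piperidine series

This account rests on a few compounds, and the source may have more. Where it says the series, first, only, none or still open, it means among the compounds named here.

Measured so far in a functional assay on isolated protein for agonist activity at Glucose-dependent insulinotropic receptor (Rattus norvegicus), read by HTRF and cAMP accumulation; on this read-out higher numbers stand for larger maximal responses and lower numbers for smaller maximal responses:
compound 1 `Cc1nc(S(C)(=O)=O)ccc1O[C@H]1CC[C@H](OC2CCN(C(=O)OC(C)C)CC2)CC1`: compound 1 gives 114%
compound 2 `Cc1nc(O[C@H]2CC[C@H](OC3CCN(C(=O)OC(C)(C)C)CC3)CC2)ccc1C(=O)N(C)C`: compound 2 gives 111%
compound 3 `C[C@H](CF)OC(=O)N1CCC(O[C@H]2CC[C@H](Oc3cnc(S(C)(=O)=O)cn3)CC2)CC1`: compound 3 gives 115%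

Compound 3 holds the largest of the three numbers, yet compound 1 and compound 2 both lie within the usual scatter of it, so no ranking among the three is supported. Compound 4 `CS(=O)(=O)c1cnc(O[C@H]2CC[C@H](OC3CCN(C(=O)C4(C(F)(F)F)CC4)CC3)CC2)cn1` differs from compound 3 only at one site: a group of 7 heavy atoms (4 carbon, 3 fluorine; one three-membered non-aromatic ring of carbon only) in place of a group of 5 heavy atoms (3 carbon, 1 oxygen, 1 fluorine; no ring), on a carbonyl carbon. The three measured compounds, carrying varied groups at the same carbonyl carbon, all give near-equal maximal responses, so this change is expected to move the number little. The estimate for compound 4 is a step of a number 3 percentage points lower from compound 3 to compound 4 (within the scatter), not beyond the scatter. Compound 4 is expected to give 112%, with a range from 100% to 124%.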

Compound 4, largest response reached (Emax), in percent of the reference or control that the assay uses: 140%
Estimate against measurement, compound 4: 28 percentage points below; measured number outside the range, above it.
By their numbers in this assay, from the lowest: compounds 2, 1 and 3 (each within the scatter of the next); then compound 4.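

The carbonyl carbon is not a silent position in this assay: placing 1-(trifluoromethyl)cyclopropyl there gives a number 25 percentage points higher from compound 3 to compound 4 (beyond the scatter). Going by these compounds alone, the maximal response at this place can therefore move beyond the scatter, which the earlier compounds did not show. Nothing shown accounts for the rise.

From the compounds shown here alone, it remains open whether the step belongs to the three-membered ring or to the trifluoromethyl group; a plain cyclopropyl and a tert-butyl on the same carbonyl carbon would separate the two. Going by these compounds, whether the step persists on the cores of compound 1 and compound 2 also remains open.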